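A few compounds are considered here, and "the series" means these few. Any claim that something is new, unique, unknown or untested is made for them only; others in the source may bear on it.

Compound 1 `O=[N+]([O-])c1cn2c(n1)[S+]([O-])CC(Oc1ccc(C(F)(F)F)cn1)C2`: > 64000 nM; 30000 nM (2 entries)
Compound 2 `O=[N+]([O-])c1cn2c(n1)[S@+]([O-])C[C@H](OCc1ccc(OC(F)(F)F)cc1)C2`: > 64000 nM

Both compounds were tested in an ADME assay on MRC5 cells (Homo sapiens) for cytotoxicity; on this read-out higher numbers stand for weaker inhibition and lower numbers for stronger inhibition. Compound 1 gives > 64000 nM; 30000 nM (2 entries). Compound 2 gives > 64000 nM, which is a limit of the assay and not a number. Compound 2 therefore has no single number in this assay, and its further entry carries none either.

The next compound, compound 3 `O=[N+]([O-])c1cn2c(n1)[S@+]([O-])C[C@@H](OCc1ccc(OC(F)(F)F)cc1)C2`, departs from compound 2 in configuration alone: the two compounds have the same atoms and bonds and differ only in configuration as drawn: 1 of 2 stereo elements differ; a stereocentre at a saturated ring carbon is drawn R in compound 2 and S in compound 3. For the measured compounds named here, no pair of measured compounds shows what such a change does in this assay, so the expectation rests on thin ground. It draws on the several entries of compound 1 in this assay, > 64000 nM; 30000 nM (2 entries) and on (the limit of > 64000 nM in this assay, at which 1 of the 2 values shown sits). On that basis no shift beyond the usual scatter is expected, and the estimated at least 1.0-fold lower number from compound 2 to compound 3 (0.02 log units; that floor lies within the scatter) is small, with no firm direction. A reading at the limit of the assay is also expected to be the likeliest outcome. For compound 3 the estimated value is 60000 nM, with an expected range from 25000 nM to 100000 nM.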

Compound 3, half-maximal inhibitory concentration: 50000 nM
The estimate for compound 3 lay 1.2-fold (0.08 log units) above the measured number, within the range that was stated.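

In this assay compound 3 gives a single number, 50000 nM, so one configuration at this saturated ring carbon, the one drawn S, now has a value that can be read as a number. Compound 2, drawn R at the same carbon, stands at > 64000 nM, which is a limit of the assay and not a number. The change of configuration therefore reads only as a floor, an at least 1.2-fold lower number from compound 2 to compound 3 (0.10 log units; that floor lies within the scatter), which shows that inverting this one stereocentre leaves both compounds weak in this read-out as far as the values go, while the true size of the gap stays unknown, and the comparison is a clean one for this single change: the fact that compounds 2 and 3 differ only in the configuration as drawn

The compounds shown leave open how large the gap between the two configurations really is, since one side of it has no number. They also leave open whether the configuration at this carbon would matter in the same way if the trifluoromethoxy group gave way to an amine or a carboxylic acid, or if the other stereo element, drawn alike in compound 2 and compound 3, were inverted.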